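Adding a fluoro to the phenyl of compound 2

The compounds below may be only part of what the source reports. "The series", "measured", "known", "first", "only" and "open" are said of these compounds alone.

In a functional assay on A549 cells (Homo sapiens) for cytotoxicity, read by MTT assay, with a stated time of 72 h (a higher number here means a weaker inhibitor, a lower number a stronger inhibitor), compound 1 `Cn1ccc2c(Oc3ccc(NC(=O)c4cc5cccnc5n(-c5ccccc5)c4=O)cc3)ncnc21` gives 66200 nM and compound 2 `Cn1ccc2c(Oc3ccc(NC(=O)c4cc5cccnc5n(-c5ccccc5)c4=O)cc3F)ncnc21` gives 63200 nM. Going by the values given here, these two numbers lie within the usual scatter of each other, so compound 2 stands level with the only other measured compound. Compound 3 `Cn1ccc2c(Oc3ccc(NC(=O)c4cc5cccnc5n(-c5ccc(F)cc5)c4=O)cc3F)ncnc21` keeps the rest of compound 2 and alters one place: fluoro in place of hydrogen on an aromatic carbon. In words, this is fluoro in place of hydrogen on an aromatic carbon, turning phenyl to 4-fluorophenyl. Among the compounds with values here, one measured step bears on it, the same kind of swap made elsewhere in the molecule: a 1.0-fold lower number from compound 1 to compound 2 (0.02 log units; within the scatter). That single step stayed within the scatter, so no change beyond the scatter is expected in this assay. The expected step is a 1.1-fold lower number from compound 2 to compound 3 (0.02 log units; within the scatter). For compound 3 the estimated value is 60000 nM, with an expected range of 28000 nM to 120000 nM.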

Compound 3, half-maximal inhibitory concentration: 7320 nM
Compound 3: the middle estimate sits 8.2-fold (0.91 log units) above what was measured, outside the stated range (below it).
By their numbers in this assay, from the lowest: compound 3; then compounds 2 and 1 (each within the scatter of the next).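

In this assay, going by these compounds alone, the phenyl ring turns out to be a place where a single fluoro counts: the change to 4-fluorophenyl gives an 8.6-fold lower number from compound 2 to compound 3 (0.94 log units; beyond the scatter) and is the first step in this set to pass beyond the scatter. The same swap on the other aromatic ring gave only a 1.0-fold lower number from compound 1 to compound 2 (0.02 log units; within the scatter), so in these compounds the outcome of adding a fluoro depends on where it is placed. No measurement here explains this difference between the two places.

Whether the drop is particular to fluoro stays open, since the compounds shown do not reveal what chloro, methoxy or an amine would do at this carbon. Also open, as far as these compounds go, is whether 4-fluorophenyl would give a similar step on compound 1, which lacks the other fluoro.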